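Moving the chlorine on the piperazine-bound phenyl ring

A few compounds are considered here, and "the series" means these few. Any claim that something is new, unique, unknown or untested is made for them only; others in the source may bear on it.

Measured compounds:
- compound 1 `CCCn1c(=O)[nH]c2nc(-c3ccc(S(=O)(=O)N4CCN(c5cccc(Br)c5)CC4)cc3)[nH]c2c1=O`: 0.234 nM
- compound 2 `CCCn1c(=O)[nH]c2nc(-c3ccc(S(=O)(=O)N4CCN(C)CC4)cc3)[nH]c2c1=O`: 48.2 nM
- compound 3 `CCCn1c(=O)[nH]c2nc(-c3ccc(S(=O)(=O)N4CCN(c5ccccc5Cl)CC4)cc3)[nH]c2c1=O`: 0.403 nM

These three compounds share one core and were tested in an assay on CHO cells for displacement of a labelled ligand from adenosine receptor A2b (Homo sapiens), read by scintillation counting, with a stated time of 75 min, in the presence of a further agent that is not named here; a lower number here means a stronger inhibitor, a higher number a weaker inhibitor. Compound 3 gives 0.403 nM, the second highest of the three numbers; its nearest neighbour is compound 1, with a 1.7-fold higher number from compound 1 to compound 3 (0.24 log units; within the scatter), and its furthest is compound 2, with a 120-fold lower number from compound 2 to compound 3 (2.08 log units; beyond the scatter). The large steps involve exchanging an aryl group for methyl: a 210-fold higher number from compound 1 to compound 2 (2.31 log units; beyond the scatter). Among the two aryl-bearing compounds the numbers lie close together.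

Compound 4 `CCCn1c(=O)[nH]c2nc(-c3ccc(S(=O)(=O)N4CCN(c5cccc(Cl)c5)CC4)cc3)[nH]c2c1=O` differs from compound 3 only in the following way: 3-chlorophenyl in place of 2-chlorophenyl on an amine nitrogen in a ring. Within the data shown here, this is again an aryl-for-aryl exchange on the same ring nitrogen, so the step that bears on it is the one from compound 1 to compound 3, which lay within the scatter. The step from compound 3 to compound 4 is therefore expected to be small, a 1.3-fold lower number from compound 3 to compound 4 (0.13 log units; within the scatter), with no clear direction. Compound 4 is estimated at 0.3 nM, within a range of 0.1 nM to 0.9 nM.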

Compound 4, inhibition constant: 0.342 nM
Estimate against measurement, compound 4: 1.1-fold (0.06 log units) below; measured number inside the range.
By their numbers in this assay, from the lowest: compounds 1, 4 and 3 (each within the scatter of the next); then compound 2.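

In this assay, taking the chlorine from 2-chlorophenyl to 3-chlorophenyl gives a 1.2-fold lower number from compound 3 to compound 4 (0.07 log units; within the scatter) and so makes no readable difference for this pair. Chloro in place of bromo on the aromatic carbon, a comparison that the earlier compounds did not offer, gives a 1.5-fold higher number from compound 1 to compound 4 (0.16 log units; within the scatter) and also stays inside the usual scatter. With methyl on the same ring nitrogen, the gap is again large, a 140-fold lower number from compound 2 to compound 4 (2.15 log units; beyond the scatter) so among these compounds the big difference lies between methyl and the halogen-bearing phenyl groups, while compound 1, compound 3 and compound 4 cannot be told apart.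

No supporting data explain why these three aryl compounds give such similar numbers. Going by these compounds, it also remains open whether a plain phenyl ring without a halogen, a methoxy group in place of the halogen, or a benzyl group on the nitrogen would keep numbers this low.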